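The source may hold more compounds than are shown below. What is called first, only, known or untested is meant among the compounds shown, and "the series" means these compounds.

Of the compounds shown here, two have been measured so far in a functional assay on HeLa cells (Homo sapiens) for antiproliferative activity; on this read-out higher numbers stand for weaker inhibition and lower numbers for stronger inhibition. Compound 1 (`CCONC(=O)c1sc(N2N=C(c3ccc(C)cc3)CC2c2cc3cc(OC)ccc3nc2Cl)nc1C`) gives 38 nM, and compound 2 (`COc1ccc2nc(-c3ccc(Br)cc3)cc(-c3nnc(Nc4ccc([N+](=O)[O-])cc4)o3)c2c1`) gives 50 nM. Among the compounds with values here, these two numbers lie within the scatter of each other, so compound 1 stands level with the only other measured compound. Compound 3 (`COc1ccc2nc(Cl)c(C3CC(c4ccc(C)cc4)=NN3c3nc(C)c(/N=N/c4ccccc4)s3)cc2c1`) keeps the rest of compound 1 and differs in one place. On an aromatic carbon of a five-membered aromatic ring with 1 nitrogen and 1 sulfur, the ethoxycarbamoyl group gives way to a group of 8 heavy atoms with one six-membered aromatic ring of carbon only (a group of 8 heavy atoms (6 carbon, 2 nitrogen; one six-membered aromatic ring of carbon only) in place of a group of 6 heavy atoms (3 carbon, 1 nitrogen, 2 oxygen; no ring), on an aromatic carbon). Within the data shown here, no measured pair shows a change of this kind, so the size of the step is only an expectation. A modest weakening in this assay is expected, and it may not exceed the scatter. The estimated change is a 2.1-fold higher number from compound 1 to compound 3 (0.32 log units; beyond the scatter). For compound 3 the expected value is 80 nM, with an estimated range from 25 nM to 300 nM.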

Compound 3, half-maximal inhibitory concentration: 38 nM
Compound 3: the middle estimate sits 2.1-fold (0.32 log units) above what was measured, and the stated range covers the measured number.
By their numbers in this assay, from the lowest: compounds 1, 3 and 2 (each within the scatter of the next).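

On the aromatic carbon next to the ring sulfur, replacing the ethoxycarbamoyl group with the group carrying the six-membered aromatic ring of carbon only gives, in this assay, no change at the digits printed from compound 1 to compound 3 (within the scatter). Within the data shown here, this position therefore accepts a group with more heavy atoms, an aromatic ring and no hydrogen-bond donor with no change beyond the scatter, which the earlier compounds could not show, as they offered no pair differing in one place. Nothing available explains this outcome.

The compounds shown leave open whether the same position would also accept a carboxylic acid, a primary amine or a longer alkyl chain. They also leave open whether this replacement would give a similar result on a core other than that of compound 1.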